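The source may hold more compounds than are shown below. What is called first, only, known or untested is meant among the compounds shown, and "the series" means these compounds.

Compound 3 `CO[C@H]1CC[C@H](CNc2cc(NCc3cnccc3C(F)(F)F)ncc2C#N)CC1` stands at the weak end of what has been seen: in an assay on isolated protein for inhibition of protein kinase C delta type (Homo sapiens), read by TR-FRET, with a stated time of 2 h (on this read-out higher numbers stand for weaker inhibition and lower numbers for stronger inhibition), compound 3 gives only a limit, > 10000 nM. Compound 1 `N#Cc1cnc(NCc2cnccc2C(F)(F)F)cc1N[C@H]1C[C@H](O)C1` also gives only a limit, > 10000 nM. Compound 2 `N#Cc1cnc(NCc2cnccc2C(F)(F)F)cc1N[C@H]1CC[C@H](O)CC1`, by contrast, gives a number, 6500 nM. The change to compound 4 `CC1(C)C[C@H](Nc2cc(NCc3cnccc3C(F)(F)F)ncc2C#N)CC[C@@H]1O` is 4-hydroxy-3,3-dimethylcyclohexyl in place of (4-methoxycyclohexyl)methyl on a nitrogen on an aromatic ring. Among the measured compounds shown here, two steps bear on it: an at least 1.5-fold higher number from compound 2 to compound 3 (0.18 log units; that floor lies within the scatter) and an at least 1.5-fold lower number from compound 1 to compound 2 (0.18 log units; that floor lies within the scatter). Compound 4 carries a hydroxy-bearing six-membered ring as compound 2 does, rather than the methoxy-bearing group of compound 3, so compound 4 is expected to return to roughly the level of compound 2, a step of an at least 2.0-fold lower number from compound 3 to compound 4 (0.30 log units; that floor lies within the scatter) in the direction of stronger inhibition. The estimate for compound 4 is 5000 nM, between 2000 nM and 12000 nM.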

Compound 4, half-maximal inhibitory concentration: 500 nM
Beside the measured number, compound 4's estimate is 10-fold (1.00 log units) above it; the measured number lies below the stated range.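

In this assay the cleanest comparison is a 13-fold lower number from compound 2 to compound 4 (1.11 log units; beyond the scatter), since both compounds carry a hydroxy-bearing six-membered ring and differ only in the two methyl groups of 4-hydroxy-3,3-dimethylcyclohexyl. This shows that substitution on this ring, on the nitrogen on the aromatic ring, can change inhibition well beyond the scatter. The other two steps, an at least 20-fold lower number from compound 3 to compound 4 (1.30 log units; beyond the scatter) and an at least 20-fold lower number from compound 1 to compound 4 (1.30 log units; beyond the scatter), are only floors, as each starts from a limit: the limit of > 10000 nM in this assay, at which 2 of the 4 values shown sit.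

The compounds shown leave open whether an amine or a carboxylic acid could stand in place of the hydroxy on the 4-hydroxy-3,3-dimethylcyclohexyl group. They also leave open whether a methoxy there would keep this strength.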